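Aroylacrylic acids with isopropyl and ethyl substitution patterns

The source may report more compounds than this note shows. Statements on the series, on what has been measured and on what is new or still open speak of the compounds shown alone.

Compound 1 `CC(C)c1ccc(C(=O)/C=C/C(=O)O)c(C(C)C)c1` and compound 3 `CCc1ccc(C(C)C)cc1C(=O)/C=C/C(=O)O` share a (2-carboxyethenyl)carbonyl group on a six-membered aromatic ring; the difference between the two cores is not broken down here. In a functional assay on LS174T cells (Homo sapiens) for inhibition, read by MTT assay, with a stated time of 72 h (on this read-out higher numbers stand for weaker inhibition and lower numbers for stronger inhibition), compound 1 gives 5360 nM and compound 3 gives 5940 nM. Compound 2 `CC(C)c1cc(C(C)C)c(C(=O)/C=C/C(=O)O)c(C(C)C)c1` carries the change isopropyl in place of hydrogen on an aromatic carbon and gives 8280 nM; the step of a 1.5-fold higher number from compound 1 to compound 2 (0.19 log units; within the scatter) is small. Compound 4 `CCc1c(C(=O)/C=C/C(=O)O)cc(C(C)C)cc1C(C)C` stands to compound 3 as isopropyl in place of hydrogen on an aromatic carbon. The surroundings differ: in compound 2 the new group sits ortho to a (2-carboxyethenyl)carbonyl group and meta to two isopropyl groups, in compound 4 ortho to an ethyl group, meta to a (2-carboxyethenyl)carbonyl group and meta to an isopropyl group, so this is the same kind of change, not the same. Resting on the step of a 1.5-fold higher number from compound 1 to compound 2 (0.19 log units; within the scatter), the step from compound 3 to compound 4 is expected to be a 1.4-fold higher number from compound 3 to compound 4 (0.16 log units; within the scatter). Compound 4 is estimated at 8500 nM in this assay.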

Compound 4, half-maximal inhibitory concentration: 12400 nM
Compound 4: the middle estimate sits 1.5-fold (0.16 log units) below what was measured; the range from low to high includes it.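

In this assay, isopropyl in place of hydrogen on an aromatic carbon gives a 2.1-fold higher number from compound 3 to compound 4 (0.32 log units; beyond the scatter), and the two cores can be set side by side: the same change on two cores in this assay, a 1.5-fold higher number (0.19 log units; within the scatter) from compound 1 to compound 2 and a 2.1-fold higher number (0.32 log units; beyond the scatter) from compound 3 to compound 4, 1.4-fold (0.13 log units) apart, within the scatter of two such steps. For the compounds shown here, the two steps cannot be told apart, so the change carries over between these two cores as far as this pair goes, although only the step to compound 4 lies beyond the scatter. Two steps give no rule for other cores, and they cannot say whether the surroundings of the new group, ortho to an ethyl group in compound 4, affect its size.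

Still open, going by these compounds, is how a methyl or methoxy group would read at that aromatic carbon. Also open, on these data alone, is how an amide in place of the carboxylic acid would read.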